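The source may report more compounds than this note shows. Statements on the series, on what has been measured and on what is new or still open speak of the compounds shown alone.

Among the measured compounds shown here, in a physicochemical assay for lipophilicity, read by HPLC (on this read-out lower numbers stand for lower lipophilicity and higher numbers for higher lipophilicity), compound 1 (`O=C1/C(=C\c2ccncc2)C(c2ccccc2)Oc2ccccc21`) reads 2.85 and compound 2 (`O=C1/C(=C\c2ccc(Cl)cc2)C(c2ccccc2)Oc2ccccc21`) stands at the top of the two numbers so far with 4.53 on this scale. For the measured compounds named here, only one measured step bears on the next change, and it is large: a number 1.68 log units higher from compound 1 to compound 2 (beyond the scatter) for 4-chlorophenyl in place of pyridin-4-yl. Compound 3 (`O=C1/C(=C\c2ccc(Br)cc2)C(c2ccccc2)Oc2ccccc21`) keeps the shared core and differs from compound 2 by bromo in place of chloro on an aromatic carbon (bromo in place of chloro on an aromatic carbon, para to a large group). The earlier step exchanged a whole aromatic ring, whereas here the ring stays and only the halogen on it changes, so a step of that earlier size is not expected. The expected step is a number 0.15 log units higher from compound 2 to compound 3 (within the scatter) and it is estimated to be small, upward and within the scatter. In this assay the estimated value for compound 3 is 4.68 with an expected range of 4.4 to 5.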

Compound 3, partition coefficient: 4.71
Compound 3: middle estimate off by 0.03 log units, on the low side; low and high end bracket the measured number.
By their numbers in this assay, from the lowest: compound 1; then compounds 2 and 3 (each within the scatter of the next).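

In this assay, exchanging the halogen on an aromatic carbon, para to a large group, gives no difference beyond the scatter: bromo in place of chloro reads (a number 0.18 log units higher from compound 2 to compound 3 (within the scatter)). The large step seen with 4-chlorophenyl in place of pyridin-4-yl recurs with the second halogen, as 4-bromophenyl in place of pyridin-4-yl reads (a number 1.86 log units higher from compound 1 to compound 3 (beyond the scatter)). At this place, the two halogens so far do not separate on this read-out, while the exchange of pyridin-4-yl does, and no measurement here offers a reason for either step.

As far as these compounds go, only two halogens occupy this aromatic carbon, so the reading for a methoxy, a nitrile or a carboxylic acid there stays open. Also open, from the compounds shown here alone, is whether a plain phenyl would read closer to compound 1 or to the pair of compound 2 and compound 3.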